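The source may report more compounds than this note shows. Statements on the series, on what has been measured and on what is new or still open speak of the compounds shown alone.

In a functional assay on MDA-MB-231 cells (Homo sapiens) for cytotoxicity, read by MTT assay, with a stated time of 72 h (a lower number here means a stronger inhibitor, a higher number a weaker inhibitor), the measured compounds give:
compound 1 `CCN(CC)Cc1ccc2nc(NC(=O)N/N=C/c3cn(Cc4ccccc4)c4ccccc34)sc2c1`: 1470 nM
compound 2 `CN(C)Cc1ccc2nc(NC(=O)N/N=C/c3cn(Cc4ccc(Cl)c(Cl)c4)c4ccccc34)sc2c1`: 1000 nM

Compound 2 stands within the usual scatter of compound 1, so neither value ranks ahead of the other. Compound 3 `CCN(CC)Cc1ccc2nc(NC(=O)N/N=C/c3cn(Cc4ccc(Cl)c(Cl)c4)c4ccccc34)sc2c1` carries diethylamino in place of dimethylamino on a saturated chain carbon bound to an aromatic carbon, counted as diethylamino in place of dimethylamino on a saturated chain carbon bound to an aromatic carbon against compound 2. For the measured compounds named here, no measured step isolates this change. Compound 1 also carries diethylamino and gives 1470 nM within the scatter of compound 2 at 1000 nM here. The expected change is a 1.1-fold higher number from compound 2 to compound 3 (0.04 log units; within the scatter) in this assay with no shift beyond the scatter. Compound 3 is estimated at 1100 nM within an expected range of 500 nM to 2400 nM for this measurement.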

Compound 3, half-maximal inhibitory concentration: 4490 nM
The estimate for compound 3 lay 4.1-fold (0.61 log units) below the measured number; the measured number lies above the stated range.
By their numbers in this assay, from the lowest: compounds 2 and 1 (each within the scatter of the next); then compound 3.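

In this assay, diethylamino in place of dimethylamino on a saturated chain carbon bound to an aromatic carbon is not a silent change on the shared core (a 4.5-fold higher number from compound 2 to compound 3 (0.65 log units; beyond the scatter)). With diethylamino held, 3,4-dichlorophenyl in place of phenyl on a saturated chain carbon bound to an aromatic nitrogen also weakens the compound (a 3.1-fold higher number from compound 1 to compound 3 (0.48 log units; beyond the scatter)), so the closeness of compound 1 and compound 2 concealed two single-place steps. Nothing on hand explains either step.

Still open, on these data alone, is whether the diethylamino step keeps its size with phenyl in place of 3,4-dichlorophenyl. Also open, as far as these compounds go, is how a pyrrolidine or morpholine in place of dimethylamino would read.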